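The source may report more compounds than this note shows. Statements on the series, on what has been measured and on what is new or still open speak of the compounds shown alone.

Measured so far: compound 1, `O=C(CCc1ccccc1)Nc1nnc(-c2ccc3c(c2)OCCO3)s1`, and compound 2, `O=C(Nc1nnc(-c2ccc3c(c2)OCCO3)s1)c1ccc(Cl)nc1`.

In a functional assay on BGC-823 cells (Homo sapiens) for antiproliferative activity, read by MTT assay, with a stated time of 48 h (a higher number here means that more compound is needed for the effect, a lower number that less compound is needed), compound 1 gives 14.2 ug/mL. As far as these compounds go, for compound 2 the result in this assay is only the limit > 100 ug/mL, as the limit of > 100 ug/mL in this assay, at which 1 of the 2 values shown sits, records, so its true number is unknown. For the measured compounds named here, compound 2 therefore stands at the weak end of the two results, and the single measured step, an at least 7.0-fold higher number from compound 1 to compound 2 (0.84 log units; beyond the scatter), is itself only a bound on the change.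

Compound 3, `Cc1ccc(C(=O)Nc2nnc(-c3ccc4c(c3)OCCO4)s2)cn1`, differs from compound 2 by methyl in place of chloro on an aromatic carbon. Going by the values given here, the one measured step concerns the exchange of phenethyl for 6-chloropyridin-3-yl and does not touch the chloro itself, so it bears on this change only by placing compound 2 beyond the limit. Among the compounds with values here, no measured step speaks to methyl against chloro, and no direction in this assay can be read from the data. The estimated step is a number no higher from compound 2 to compound 3 (the limit leaves the size open). Compound 3 is therefore expected near the limit, at an estimated 100 ug/mL, with a range from 30 ug/mL to 300 ug/mL.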

Compound 3, half-maximal effective concentration: > 100 ug/mL
Compound 3: no number, only a limit; the forecaster's own chance of this, stated with the estimate: 60%; the middle value lies on the limit itself.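

In this assay compound 3 gives > 100 ug/mL, which is a limit and not a number. The step between compound 2 and compound 3 cannot be read, so on this aromatic carbon next to the ring nitrogen, neither chloro nor methyl brings a number within the range of the assay. With 6-methylpyridin-3-yl in place of phenethyl on the carbonyl carbon, the result is an at least 7.0-fold higher number from compound 1 to compound 3 (0.84 log units; beyond the scatter), and a second compound now rests on the same limit: the limit of > 100 ug/mL in this assay, at which 2 of the 3 values shown sit.

As far as these compounds go, how far beyond the limit compound 2 and compound 3 lie, and whether they differ from each other, remains open. Also open, from the compounds shown here alone, is whether an amine or a methoxy group in place of the chloro, or a longer chain in place of the 6-methylpyridin-3-yl group, would give a measurable number in this assay.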